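From 1-(pyridin-2-yl)ethyl to pyrazin-2-yl on the shared core

A few compounds are considered here, and "the series" means these few. Any claim that something is new, unique, unknown or untested is made for them only; others in the source may bear on it.

Within the data shown here, in a functional assay (blood) for inhibition, with Homo sapiens as the target (on this read-out higher numbers stand for weaker inhibition and lower numbers for stronger inhibition), compound 2 (`C[C@H](COc1ccc2c(c1)c(SC(C)(C)C)c(CC(C)(C)C(=O)O)n2Cc1ccc(Cl)cc1)c1ccccn1`) gives 470 nM, the lowest of the two numbers so far, while compound 1 (`CC(C)(C)Sc1c(CC(C)(C)C(=O)O)n(Cc2ccc(Cl)cc2)c2ccc(OCc3ccc4cnccc4n3)cc12`) gives 980 nM. In compound 3 (`CC(C)(C)Sc1c(CC(C)(C)C(=O)O)n(Cc2ccc(Cl)cc2)c2ccc(OCc3cnccn3)cc12`), not yet measured, pyrazin-2-yl stands in place of 1-(pyridin-2-yl)ethyl on a saturated chain carbon bound to an oxygen on an aromatic ring (pyrazin-2-yl in place of 1-(pyridin-2-yl)ethyl on a saturated chain carbon bound to an oxygen on an aromatic ring). Among the measured compounds shown here, only one measured step bears on this change: a 2.1-fold lower number from compound 1 to compound 2 (0.32 log units; beyond the scatter), a modest step at that same place. For the measured compounds named here, no measured compound carries pyrazin-2-yl, so the expectation is loose. Compound 1 also lacks 1-(pyridin-2-yl)ethyl and sits on the higher side of that step, so a modest move to a higher number in this assay is expected. The estimated change is a 1.9-fold higher number from compound 2 to compound 3 (0.28 log units; within the scatter). For compound 3 the expected value is 900 nM, with an estimated range of 350 nM to 2400 nM.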

Compound 3, half-maximal inhibitory concentration: 400 nM
For compound 3 the middle estimate is 2.3-fold (0.35 log units) above the measured one, and the stated range covers the measured number.
By their numbers in this assay, from the lowest: compounds 3 and 2 (each within the scatter of the next); then compound 1.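

In this assay, pyrazin-2-yl in place of 1-(pyridin-2-yl)ethyl on a saturated chain carbon bound to an oxygen on an aromatic ring gives a 1.2-fold lower number from compound 2 to compound 3 (0.07 log units; within the scatter) and so leaves the two compounds indistinguishable, even though the entering group has fewer heavy atoms and no defined stereocentre. Against the two-ring group of compound 1, pyrazin-2-yl gives a 2.5-fold lower number from compound 1 to compound 3 (0.39 log units; beyond the scatter) as its step, so both one-ring groups now stand on the lower side of that group, and none of the three compounds goes against this. Nothing shown here explains these numbers.

On these data alone, whether the defined stereocentre of compound 2 matters at all remains open. So does whether a plain phenyl ring, or a ring carrying an amine or a carboxylic acid, would keep the number in this range at this place.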